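Methyl to benzyl on compound 2

The compounds below may be only part of what the source reports. "The series", "measured", "known", "first", "only" and "open" are said of these compounds alone.

Compound 1 `CCCCCCCCCc1ccc(OP(=O)(O)OC[C@H]2O[C@@H](n3cc(F)c(=O)[nH]c3=O)C[C@@H]2OC(=O)c2ccccc2)cc1`: 20400 nM
Compound 2 `C[n+]1cccc(OP(=O)([O-])OC[C@H]2O[C@@H](n3cc(F)c(=O)[nH]c3=O)C[C@@H]2OC(=O)c2ccccc2)c1`: 1380 nM

In a functional assay on Caco-2 cells (Homo sapiens) for cytotoxicity, read by MTT assay, with a stated time of 48 h (a higher number here means a weaker inhibitor, a lower number a stronger inhibitor), compound 1 gives 20400 nM and compound 2 gives 1380 nM, the lower of the two numbers. The gap between these two compounds lies beyond the scatter. Compound 3 `O=C(O[C@H]1C[C@H](n2cc(F)c(=O)[nH]c2=O)O[C@@H]1COP(=O)([O-])Oc1ccc[n+](Cc2ccccc2)c1)c1ccccc1` differs from compound 2 by phenyl in place of hydrogen on a saturated chain carbon bound to an aromatic nitrogen, which turns methyl into benzyl. Within the data shown here, no measured pair shows this change on its own, so its size is uncertain. A small rise in the number is expected in this assay, possibly none beyond the scatter. The expected change is a 1.4-fold higher number from compound 2 to compound 3 (0.16 log units; within the scatter). For compound 3 the estimated value is 2000 nM, with an expected range of 500 nM to 8000 nM.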

Compound 3, half-maximal inhibitory concentration: 430 nM
Estimate against measurement, compound 3: 4.7-fold (0.67 log units) above; the measured number lies below the stated range.
By their numbers in this assay, from the lowest: compound 3; then compound 2; then compound 1.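

Within this assay the change from methyl to benzyl on a saturated chain carbon bound to an aromatic nitrogen gives a 3.2-fold lower number from compound 2 to compound 3 (0.51 log units; beyond the scatter) and so lies beyond the scatter. Among these compounds, this is the first view of this position, and it shows that the added phenyl goes with a lower number, not a higher one. Nothing measured here accounts for the step.

As far as these compounds go, whether a longer chain such as phenethyl would lower the number further stays open. So does whether a benzyl carrying a methoxy group or a fluorine on its phenyl would keep the step.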